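The compounds below may be only part of what the source reports. "The series", "measured", "known", "first", "only" and "open" are said of these compounds alone.

Values measured so far in a functional assay on HOP-92 cells (Homo sapiens) for inhibition; a higher number here means a weaker inhibitor of growth, a lower number a stronger inhibitor of growth

Compound 1 (`C=C1C(=O)O[C@H]2[C@H]1CC/C(COC(=O)N1CCC(F)(F)CC1)=C\CC[C@@]1(C)O[C@@H]21`) gives 1450 nM

Compound 2 (`C=C1C(=O)O[C@H]2[C@H]1CC/C(COC(=O)NCCN1CCCC1)=C\CC[C@@]1(C)O[C@@H]21`) gives 2250 nM

Compound 2 cannot be ranked against compound 1, since the two numbers lie within the scatter of each other. Compound 3 (`C=C1C(=O)O[C@H]2[C@H]1CC/C(COC(=O)Nc1n[nH]c(SC)n1)=C\CC[C@@]1(C)O[C@@H]21`) has not been measured yet. Its difference from compound 2 is 5-(methylsulfanyl)-1H-1,2,4-triazol-3-yl in place of 2-(pyrrolidin-1-yl)ethyl on an amide-type nitrogen and the change sits on an amide-type nitrogen, where 5-(methylsulfanyl)-1H-1,2,4-triazol-3-yl takes the place of 2-(pyrrolidin-1-yl)ethyl. Among the measured compounds shown here, the incoming group has an aromatic ring, and neither measured compound has one in this part of the molecule, so no measured step tests this change directly. For the measured compounds named here, the closest evidence is the single step available, in which replacing 4,4-difluoropiperidin-1-yl with (2-(pyrrolidin-1-yl)ethyl)amino on a carbonyl carbon gave a 1.6-fold higher number from compound 1 to compound 2 (0.19 log units; within the scatter) and stayed small. One step is thin support, but it gives no reason to expect a shift beyond the scatter in this assay in either direction. The expected change is a 1.3-fold lower number from compound 2 to compound 3 (0.10 log units; within the scatter) and remains only an estimate. Compound 3 is expected at 1800 nM within an estimated range of 600 nM to 5000 nM for now.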

Compound 3, concentration for 50% growth inhibition: 650 nM
Beside the measured number, compound 3's estimate is 2.8-fold (0.44 log units) above it; the range from low to high includes it.
By their numbers in this assay, from the lowest: compound 3; then compounds 1 and 2 (each within the scatter of the next).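

In this assay, the group on the amide-type nitrogen now makes a difference that lies beyond the scatter: 5-(methylsulfanyl)-1H-1,2,4-triazol-3-yl in place of 2-(pyrrolidin-1-yl)ethyl gives a 3.5-fold lower number from compound 2 to compound 3 (0.54 log units; beyond the scatter). The comparison with the group on the carbonyl carbon of the first compound points the same way, with (5-(methylsulfanyl)-1H-1,2,4-triazol-3-yl)amino in place of 4,4-difluoropiperidin-1-yl giving a 2.2-fold lower number from compound 1 to compound 3 (0.35 log units; beyond the scatter). Both steps are modest, but compound 3 is the strongest inhibitor of growth of the three, so this part of the molecule can be changed to shift the read-out, which compounds 1 and 2 alone could not show. No measurement shown here explains why the number falls.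

The five-membered aromatic ring and its methylsulfanyl group enter together, so the compounds shown cannot say how much each one contributes. A close relative with a methyl group or a plain hydrogen in place of the methylsulfanyl, or a phenyl ring on the same nitrogen, would help to separate the two.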